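The source may hold more compounds than are shown below. What is called first, only, known or untested is meant among the compounds shown, and "the series" means these compounds.

Measured so far in an assay on isolated protein for inhibition of acyl-CoA desaturase 1 (Rattus norvegicus); on this read-out higher numbers stand for weaker inhibition and lower numbers for stronger inhibition:
compound 1, `O=C(O)c1cncc(-c2ccc(N3CCC(Oc4ccccc4C(F)(F)F)CC3)nn2)c1`: 129 nM
compound 2, `O=C(O)c1cncc(-c2ccc(N3CCC(Oc4ccccc4I)CC3)nn2)c1`: 27 nM

Going by the values given here, compound 2 stands lowest of the two numbers; the only step, a 4.8-fold lower number from compound 1 to compound 2 (0.68 log units; beyond the scatter), separates it from compound 1. Compound 3, `O=C(O)c1cncc(-c2ccc(N3CCC(Oc4c(F)cc(F)cc4Br)CC3)nn2)c1`, carries 2-bromo-4,6-difluorophenyl in place of 2-iodophenyl on an oxygen on a saturated carbon. Among the compounds with values here, the one measured step, a 4.8-fold lower number from compound 1 to compound 2 (0.68 log units; beyond the scatter), touches the same ring but swaps a different group, so it bears on compound 3 only loosely; no step shows the added fluorines. A step near the scatter is therefore expected, a 1.5-fold higher number from compound 2 to compound 3 (0.17 log units; within the scatter), with no firm direction. For compound 3 in this assay the estimate is 40 nM, within 15 nM to 120 nM.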

Compound 3, half-maximal inhibitory concentration: > 20000 nM
Compound 3: a limit, no number; the forecaster's own chance of this, stated with the estimate: 5%; middle value at least 500-fold (2.69 log units) away from the limit.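

In this assay compound 3 gives > 20000 nM, a limit and not a number. The group on this oxygen can therefore do far more than shift the read-out modestly: 2-bromo-4,6-difluorophenyl gives an at least 740-fold higher number from compound 2 to compound 3 (2.86 log units; beyond the scatter) and an at least 150-fold higher number from compound 1 to compound 3 (2.19 log units; beyond the scatter), both large, whereas the earlier change of group gave only a 4.8-fold lower number from compound 1 to compound 2 (0.68 log units; beyond the scatter). Compound 3 shows that activity at this position can be lost almost entirely through the aryl group alone, with the core unchanged.

Bromo in place of iodo and the added fluorines arrive together, so the step cannot be assigned to either. A 2-bromophenyl group on the same oxygen would separate them.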